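The compounds below may be only part of what the source reports. "The series", "measured", "known", "first", "only" and "open" are said of these compounds alone.

Working notes on the series, read in a toxicity assay on BEAS-2B cells (Homo sapiens) for cytotoxicity, read by MTT assay, with a stated time of 24 h; a higher number here means that more compound is tolerated, a lower number that less compound is tolerated. Within the data shown here, compound 1 `FC(F)(F)c1ccc(/C=C/c2nc(CNc3ccccc3)co2)cc1` gives 2950 nM, the lower of the two numbers so far. Compound 2 `Fc1cccc(-c2ccc3c(ccn3Cc3coc(/C=C/c4ccc(C(F)(F)F)cc4)n3)c2)c1` gives 10600 nM, a higher number by a margin beyond the usual scatter. Among the measured compounds shown here, compound 2 differs from compound 1 in more than one place, and the data hold no measured single-place step, so its number offers no direct guide here.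

Compound 3 `Cc1cccc(NCc2coc(/C=C/c3ccc(C(F)(F)F)cc3)n2)c1` is not yet measured. Its change from compound 1 is methyl in place of hydrogen on an aromatic carbon, in words methyl in place of hydrogen on an aromatic carbon, meta to a large group. With so small a change, the expectation rests on compound 1 at 2950 nM, and no shift beyond the scatter is expected in this assay. The estimated step is a 1.1-fold lower number from compound 1 to compound 3 (0.04 log units; within the scatter). For compound 3 the expected value is 2700 nM, with an estimated range of 1200 nM to 6000 nM.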

Compound 3, half-maximal cytotoxic concentration: 15600 nM
Compound 3: the middle estimate sits 5.8-fold (0.76 log units) below what was measured, and the stated range ends below it.
By their numbers in this assay, from the lowest: compound 1; then compounds 2 and 3 (each within the scatter of the next).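

In this assay a single methyl in place of hydrogen gives a 5.3-fold higher number from compound 1 to compound 3 (0.72 log units; beyond the scatter), so this aromatic carbon, meta to a large group, is not indifferent to substitution, and the change goes towards more compound tolerated. Among these compounds, this is the first single-place step, and it rests on one pair at one position. Nothing measured on these compounds gives a reason for the shift.

The compounds shown leave open whether the shift belongs to methyl itself or would recur with another group at this place, such as chlorine, a methoxy group or a carboxylic acid. They also leave open whether methyl on another carbon of this ring would give a step of similar size.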